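Swapping the Group on the Amide Nitrogen

The compounds below may be only part of what the source reports. "The series", "measured", "known", "first", "only" and "open" are said of these compounds alone.

Measured in a functional assay on CLL cells (Homo sapiens) for cytotoxicity, read by MTT assay, with a stated time of 48 h; on this read-out higher numbers stand for an effect only at larger amounts of compound and lower numbers for an effect already at smaller amounts:
- Compound 1 `C=C(CC)C(=O)c1ccc(OCC(=O)Nc2ccc(S(=O)(=O)O)cc2)c(Cl)c1Cl`: > 25000 nM (a limit of the assay)
- Compound 2 `C=C(CC)C(=O)c1ccc(OCC(=O)NCO[N+](=O)[O-])c(Cl)c1Cl`: 4100 nM

Among the measured compounds shown here, of the two compounds tested so far in this assay, only compound 2 has a true number, at 4100 nM. Compound 1 reads > 25000 nM, and that value is a limit. For the measured compounds named here, no two measured compounds differ in one place only, so no measured step guides what follows.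

Compound 3 `C=C(CC)C(=O)c1ccc(OCC(=O)Nc2ccc(C(N)=O)cc2)c(Cl)c1Cl` has not yet been measured. It carries 4-carbamoylphenyl in place of (nitrooxy)methyl on an amide-type nitrogen. Compound 1 also has a six-membered aromatic ring of carbon on that nitrogen. With compound 1 at > 25000 nM, a limit, compound 3 is expected to need a larger amount than compound 2, though a single comparison gives only weak support. The change is expected to be moderate and is estimated as a 2.2-fold higher number from compound 2 to compound 3 (0.34 log units; beyond the scatter). The value estimated for compound 3 is 9000 nM, with an expected range from 2500 nM to 25000 nM.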

Compound 3, half-maximal effective concentration: 3700 nM
Compound 3: middle estimate off by 2.4-fold (0.39 log units), on the high side; measured number inside the range.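

In this assay, the group on the amide-type nitrogen can change from an open chain to a ring-bearing group with no change beyond the scatter, as the step shows: a 1.1-fold lower number from compound 2 to compound 3 (0.04 log units; within the scatter). With a six-membered aromatic ring of carbon kept on that nitrogen, carbamoyl in place of sulfo on an aromatic carbon gives an at least 6.7-fold lower number from compound 1 to compound 3 (0.82 log units; beyond the scatter), so that ring alone does not set the poor reading of compound 1, and the group it carries counts at this position. The true size of that step stays unknown, since compound 1 defines it only through a limit of the assay: the limit of > 25000 nM in this assay, at which 1 of the 3 values shown sits.

On these data alone, it remains open how a carboxylic acid or an amine would read in place of carbamoyl on that ring, and so whether sulfo stands alone among such groups or marks a wider trend. Also open, as far as these compounds go, is whether a plain methyl or a longer chain on the amide-type nitrogen would read like (nitrooxy)methyl, which would show whether the nitrooxy part of compound 2 matters in this assay.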